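The source may hold more compounds than are shown below. What is called first, only, known or untested is meant among the compounds shown, and "the series" means these compounds.

Measured so far in a functional assay on MDA-MB-231 cells (Homo sapiens) for antiproliferative activity, read by XTT assay; on this read-out lower numbers stand for stronger inhibition and higher numbers for weaker inhibition:
Compound 1 `O=c1c(Cc2coc3cccc(OCC4CCCCC4)c3c2=O)coc2ccccc12` gives 4110 nM.
Compound 2 `O=c1c(Cc2coc3cccc(OCC4CCCCC4)c3c2=O)coc2cc(Cl)ccc12` gives only a limit of this assay, > 10000 nM.
Compound 3 `Cc1ccc2c(=O)c(Cc3coc4cccc(OCC5CCCCC5)c4c3=O)coc2c1` gives 3320 nM.

Among the two plain numbers, compound 1 holds the higher one; the step of a 1.2-fold lower number from compound 1 to compound 3 (0.09 log units; within the scatter) lies within the scatter, so the two cannot be ordered. The unmeasured compound 4 `O=c1c(Cc2coc3cccc(OCC4CCCCC4)c3c2=O)coc2cc(O)ccc12` differs from compound 1 by hydroxy in place of hydrogen on an aromatic carbon. Among the measured compounds shown here, two measured steps touch the same place on the shared core: an at least 2.4-fold higher number from compound 1 to compound 2 (0.38 log units; beyond the scatter), and a 1.2-fold lower number from compound 1 to compound 3 (0.09 log units; within the scatter). The step of an at least 3.0-fold lower number from compound 2 to compound 3 (0.47 log units; beyond the scatter) shows how far the two substituents at that place drift apart. Chloro therefore weakened inhibition, while methyl left it unchanged, and one of the three values is only a limit (the limit of > 10000 nM in this assay, at which 1 of the 3 values shown sits), so the hydroxy of compound 4 has no direct precedent. The expectation is a step of a 1.2-fold higher number from compound 1 to compound 4 (0.09 log units; within the scatter), close to no change, with wide uncertainty. Compound 4 is estimated at 5000 nM, within a range of 1500 nM to 15000 nM.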

Compound 4, half-maximal inhibitory concentration: 3220 nM
Compound 4: the middle estimate sits 1.6-fold (0.19 log units) above what was measured, and the stated range covers the measured number.
By their numbers in this assay, from the lowest: compounds 4, 3 and 1 (each within the scatter of the next). At a limit, above all of these: compound 2.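

In this assay, hydroxy on this aromatic carbon shows no readable difference from hydrogen or from methyl: a 1.3-fold lower number from compound 1 to compound 4 (0.11 log units; within the scatter) and a 1.0-fold lower number from compound 3 to compound 4 (0.01 log units; within the scatter) both lie within the scatter, so this place tolerates a group that carries a hydrogen-bond donor and acceptor. Chloro now stands apart from all three other substituents, as hydroxy also gives an at least 3.1-fold lower number from compound 2 to compound 4 (0.49 log units; beyond the scatter). The true size of that gap remains unknown, as the value for compound 2 is only a limit: the limit of > 10000 nM in this assay, at which 1 of the 4 values shown sits.

What the compounds shown leave open is whether chloro is a lone exception at this place, or whether bromo or trifluoromethyl would weaken inhibition as well. How an amine, a carboxylic acid or a longer chain such as butoxy would fare here is also open, and the four compounds give no reason for the effect of chloro.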